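This account rests on a few compounds, and the source may have more. Where it says the series, first, only, none or still open, it means among the compounds named here.

Measured so far in an assay for binding affinity to Neuropeptide Y receptor type 5 (Homo sapiens); on this read-out lower numbers stand for stronger inhibition and higher numbers for weaker inhibition:
compound 1 `O=C(Nc1cc(-c2ccccc2Cl)n[nH]1)C1Cc2ccccc2C1`: 450 nM
compound 2 `COc1ccc(-c2cc(NC(=O)C3Cc4ccccc4C3)[nH]n2)cc1OC`: 33 nM

Compound 1 stands at the higher of the two numbers; compound 2 sits well below it, beyond the scatter. Compound 3 `O=C(Nc1cc(-c2cccc(Cl)c2)n[nH]1)C1Cc2ccccc2C1` keeps the core of compound 1 and differs only in the aryl group: 3-chlorophenyl in place of 2-chlorophenyl on an aromatic carbon. Among the compounds with values here, no step between two measured compounds shows the effect of moving the chlorine, so the direction rests on the two numbers alone. Compound 2 reaches 33 nM with substituents elsewhere on its phenyl ring, which leaves a modest improvement plausible. Compound 3 is estimated at 220 nM, within 60 nM to 900 nM, a step of a 2.0-fold lower number from compound 1 to compound 3 (0.31 log units; beyond the scatter) that may still fall inside the scatter.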

Compound 3, inhibition constant: 120 nM
Beside the measured number, compound 3's estimate is 1.8-fold (0.26 log units) above it, within the range that was stated.
By their numbers in this assay, from the lowest: compound 2; then compound 3; then compound 1.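

In this assay, 3-chlorophenyl in place of 2-chlorophenyl on an aromatic carbon gives a 3.8-fold lower number from compound 1 to compound 3 (0.57 log units; beyond the scatter). Within the data shown here, this is the first direct comparison at this position, and it shows that the number responds to where the chlorine sits on the phenyl ring, even though the two compounds have the same atoms. Nothing available gives a reason for this step.

Going by these compounds, whether an amine or a carboxylic acid in place of the chlorine would lower the number further stays open. So does how the rest of the shared core responds to change.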